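The source may hold more compounds than are shown below. What is called first, only, known or untested is meant among the compounds shown, and "the series" means these compounds.

Compound 1 `C#CCSc1nc(Nc2ccccc2Cl)c(C#N)c(-c2ccccc2)n1` gives 24200 nM in a functional assay on MCF7 cells (Homo sapiens) for inhibition, read by MTT assay, with a stated time of 72 h; a higher number here means a weaker inhibitor, a lower number a stronger inhibitor. Compound 2 `C#CCSc1nc(Nc2ccc(Cl)cc2)c(C#N)c(-c2ccccc2)n1` is read only as a limit in this assay, where compound 2 gives > 128000 nM and no number. The step between them, an at least 5.2-fold higher number from compound 1 to compound 2 (0.72 log units; beyond the scatter), follows (4-chlorophenyl in place of 2-chlorophenyl on a nitrogen on an aromatic ring), so the change weakens inhibition at least modestly.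

Compound 3 `N#Cc1c(Nc2ccccc2Cl)nc(SCc2cn(Cc3ccccc3Cl)nn2)nc1-c1ccccc1` gives 1950 nM in this assay, the lowest number of the two measured. The difference between the core of compound 3 and that of compound 1 is not broken down here.

Compound 4 `N#Cc1c(Nc2ccc(Cl)cc2)nc(SCc2cn(Cc3ccccc3Cl)nn2)nc1-c1ccccc1` is not yet measured. Against compound 3 it shows (4-chlorophenyl in place of 2-chlorophenyl on a nitrogen on an aromatic ring), the same change as seen once already from compound 1 to compound 2. The step is expected to run in the same direction, an 8.2-fold higher number from compound 3 to compound 4 (0.91 log units; beyond the scatter), because the earlier pairing gave an at least 5.2-fold higher number from compound 1 to compound 2 (0.72 log units; beyond the scatter). Given (the limit of > 128000 nM in this assay, at which 1 of the 3 values shown sits), one of the three known values already sits at the upper edge, so a limit is a possibility for compound 4 too. For compound 4 the expected value in this assay is 16000 nM, estimated between 4000 nM and 60000 nM.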

Compound 4, half-maximal inhibitory concentration: 6520 nM
Compound 4: middle estimate off by 2.5-fold (0.39 log units), on the high side; measured number inside the range.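

In this assay, 4-chlorophenyl in place of 2-chlorophenyl on the nitrogen gives a 3.3-fold higher number from compound 3 to compound 4 (0.52 log units; beyond the scatter), so the change weakens inhibition on this core too, and the direction carries over between the two cores shown: the same change on two cores in this assay, an at least 5.2-fold higher number (0.72 log units; beyond the scatter) from compound 1 to compound 2 and a 3.3-fold higher number (0.52 log units; beyond the scatter) from compound 3 to compound 4; the limit leaves it open whether they differ. The size of the step cannot be compared between the cores, since compound 2 is read only as a limit: the limit of > 128000 nM in this assay, at which 1 of the 4 values shown sits. Two pairs show that the change ran the same way on these two cores, but they set no rule for any other core and do not show why the 4-chlorophenyl compounds give the higher numbers.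

The compounds shown leave open how other groups on that nitrogen would read, such as an unsubstituted phenyl, a methoxyphenyl or a cyclohexyl group in place of the chlorophenyl. On these data alone, it also remains open whether the same step would hold on a core carrying a carboxylic acid or a longer chain where the cores of compound 1 and compound 3 differ.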